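The source may report more compounds than this note shows. Statements on the series, on what has been measured and on what is new or still open speak of the compounds shown alone.

Compound 1 `C=CS(=O)(=O)N1CCN(c2ncnc3sc(-c4ccc(OC)cc4)cc23)CC1` gives 28400 nM in a functional assay on MDA-MB-436 cells (Homo sapiens) for antiproliferative activity, read by MTT assay, with a stated time of 48 h; on this read-out lower numbers stand for stronger inhibition and higher numbers for weaker inhibition. Compound 2 `C=CS(=O)(=O)N1CCN(c2ncnc3sc(-c4ccc(C#N)cc4)cc23)CC1` differs by one change, (cyano in place of methoxy on an aromatic carbon), and gives 9170 nM in this assay, which amounts to a 3.1-fold lower number from compound 1 to compound 2 (0.49 log units; beyond the scatter). Compound 3 `COc1ccc(NC(=O)N2CCN(c3ncnc4sc(-c5ccc(N6CCN(C)CC6)cc5)cc34)CC2)cc1` is built on another core; the difference between the two cores is not broken down here. In this assay compound 3 gives 30100 nM, within the scatter of compound 1 and separated from compound 2 by a gap beyond the scatter. Compound 4 `CN1CCN(c2ccc(-c3cc4c(N5CCN(C(=O)Nc6ccc(C#N)cc6)CC5)ncnc4s3)cc2)CC1` repeats on the core of compound 3 the change already seen, (cyano in place of methoxy on an aromatic carbon); the surroundings of the place read alike, so this is the same change. On the strength of the earlier measured step, the expected step is a 2.7-fold lower number from compound 3 to compound 4 (0.44 log units; beyond the scatter), resting on a single prior instance. Compound 4 is expected at 11000 nM, with a likely range from 4000 nM to 30000 nM.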

Compound 4, half-maximal inhibitory concentration: 5010 nM
Compound 4: the middle estimate sits 2.2-fold (0.34 log units) above what was measured, and the stated range covers the measured number.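

In this assay, cyano in place of methoxy on the aromatic carbon gives a 6.0-fold lower number from compound 3 to compound 4 (0.78 log units; beyond the scatter), so the number falls in the same direction on both cores. The two steps do not differ in size beyond what the scatter allows: the same change on two cores in this assay, a 3.1-fold lower number (0.49 log units; beyond the scatter) from compound 1 to compound 2 and a 6.0-fold lower number (0.78 log units; beyond the scatter) from compound 3 to compound 4, 1.9-fold (0.29 log units) apart, within the scatter of two such steps. This supports carrying the change between these two cores, but it rests on two pairs in one cell assay and does not show why the number falls or that the step would hold on any further core.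

The compounds shown leave open how fluorine, trifluoromethyl or an amine would read at the same place. They also leave open whether the step persists on other cores.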